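Methoxyphenyl for fluorophenyl on the benzylic carbon

The source may hold more compounds than are shown below. What is called first, only, known or untested is meant among the compounds shown, and "the series" means these compounds.

Measured compounds:
compound 1 `CCc1cc(Nc2nc(N[C@@H](C)c3cccc(F)c3)nc3ccccc23)n[nH]1`, 340 nM
compound 2 `CCc1cc(Nc2nc(NCc3ccc(F)cc3)nc3ccccc23)n[nH]1`, 250 nM
compound 3 `CCc1cc(Nc2nc(N[C@@H](C)c3ncc(F)cn3)nc3cccc(F)c23)n[nH]1`, 230 nM

In an assay on isolated protein for inhibition of G protein-coupled receptor kinase 6 (Homo sapiens), read by scintillation counting, radiometric assay and 33P incorporation, with a stated time of 80 min, in the presence of a further agent that is not named here (a higher number here means a weaker inhibitor, a lower number a stronger inhibitor), compound 1 gives 340 nM. On paper this is the highest of the three numbers, but the gap to compound 2 is small, a 1.4-fold lower number from compound 1 to compound 2 (0.13 log units; within the scatter), and compound 3 with 230 nM is likewise within the scatter of compound 1, so the three cannot be ranked.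

Compound 4 `CCc1cc(Nc2nc(N[C@@H](C)c3ccc(OC)cc3)nc3ccccc23)n[nH]1` is not yet measured. It differs from compound 1 in one place: 4-methoxyphenyl in place of 3-fluorophenyl on a saturated chain carbon bound to a nitrogen on an aromatic ring and a saturated chain carbon. Going by the values given here, the only measured step that touches the same part of the shared core is the one from compound 1 to compound 2, where a 4-fluorobenzyl replaced the 1-(3-fluorophenyl)ethyl group, and that step stayed within the scatter. Among the compounds with values here, no measured pair exchanges a fluorine for a methoxy on this ring, so there is no direct precedent for the present change. Given that the one related step was flat, compound 4 is expected to give a number close to that of compound 1, with a 1.0-fold higher number from compound 1 to compound 4 (0.01 log units; within the scatter) not beyond the scatter. The estimate for compound 4 in this assay is therefore 350 nM, with a range from 150 nM to 850 nM.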

Compound 4, half-maximal inhibitory concentration: 290 nM
Beside the measured number, compound 4's estimate is 1.2-fold (0.08 log units) above it, within the range that was stated.
By their numbers in this assay, from the lowest: compounds 3, 2, 4 and 1 (each within the scatter of the next).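

In this assay, replacing 3-fluorophenyl with 4-methoxyphenyl on the saturated chain carbon gives a 1.2-fold lower number from compound 1 to compound 4 (0.07 log units; within the scatter), so this exchange of the aromatic group leaves compound 1 and compound 4 indistinguishable. Unlike the earlier step from compound 1 to compound 2, it leaves the rest of the substituent intact, which shows that this position accepts a larger aromatic group carrying a hydrogen-bond acceptor, with no readable difference in this one assay. No supporting measurement bears on why the two compounds read alike.

The step exchanges the whole 3-fluorophenyl group for the whole 4-methoxyphenyl group, so the contribution of the substituent cannot be separated from that of its location on the ring, and the agreement between the two numbers does not show that either one is without effect. As far as these compounds go, it also remains open whether this tolerance extends to groups of another kind on that phenyl ring, such as a carboxylic acid, an amine or a longer chain, or to the same exchange on a different core, such as that of compound 3.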